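The compounds below may be only part of what the source reports. "The series", "measured", "known", "first", "only" and "open" are said of these compounds alone.

Of the compounds shown here, three built on one shared core have been measured in a functional assay on MGC-803 cells (Homo sapiens) for inhibition, read by sulforhodamine B assay; on this read-out higher numbers stand for weaker inhibition and lower numbers for stronger inhibition. Compound 1 `Cc1ccc(NC2=CC(=O)c3c(nc4n3[C@H]3OC[C@@H](O)[C@H]3OC4)C2=O)cc1C` gives 1050 nM. Going by the values given here, compound 2 `COc1ccc(NC2=CC(=O)c3c(nc4n3[C@H]3OC[C@@H](O)[C@H]3OC4)C2=O)cc1` gives 2150 nM, and the single change between these two, a 2.0-fold higher number from compound 1 to compound 2 (0.31 log units; beyond the scatter), is the only one-step comparison available. Compound 3 `O=C1C=C(NCc2ccccc2)C(=O)c2c1nc1n2[C@H]2OC[C@@H](O)[C@H]2OC1` gives 2670 nM, the highest of the three numbers; its gap to compound 2 lies within the scatter, while its gap to compound 1 lies beyond it.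

Compound 4 `CCCN(CCC)C1=CC(=O)c2nc3n(c2C1=O)[C@H]1OC[C@@H](O)[C@H]1OC3` is the next compound. Relative to compound 3 it carries dipropylamino in place of benzylamino on a double-bonded ring carbon. Among the compounds with values here, the one measured step swapped one aromatic group for another on the amine nitrogen and shifted the number by a modest amount; it says nothing about a change that removes the aromatic ring and the hydrogen-bond donor altogether, so the footing for a forecast is thin. The spread across all three measured compounds in this assay is narrow, so the step for compound 4 is expected to be small, most likely drifting toward a higher number but not surely beyond the scatter. The expected result for compound 4 is 3500 nM, within a range from 1500 nM to 8500 nM. This amounts to an estimated step of a 1.3-fold higher number from compound 3 to compound 4 (0.12 log units; within the scatter).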

Compound 4, half-maximal inhibitory concentration: > 16000 nM
Compound 4: a limit, no number; the forecaster's own chance of this, stated with the estimate: 10%; at least 4.5-fold (0.66 log units) between middle value and limit.
By their numbers in this assay, from the lowest: compound 1; then compounds 2 and 3 (each within the scatter of the next). At a limit, above all of these: compound 4.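

The position on the double-bonded ring carbon is not indifferent to the group it carries: compounds 1, 2 and 3, which all have an aromatic ring and an amine hydrogen there, span only a narrow range of numbers, yet the latest change gives an at least 5.9-fold higher number from compound 3 to compound 4 (0.77 log units; beyond the scatter). Compound 4 has no exact number, only a limit of the assay, so this step marks a minimum size and the real loss of inhibition could be larger: the limit of > 16000 nM in this assay, at which 1 of the 4 values shown sits. The change from benzylamino to dipropylamino also differs in kind from the earlier step, which replaced one aromatic group with another, since it takes away both the six-membered aromatic ring and the hydrogen-bond donor in a single move.

The compounds shown cannot tell whether losing the ring, losing the donor, or losing both together accounts for this step. A propylamino group, which keeps the donor without the ring, and a benzyl(methyl)amino group, which keeps the ring without the donor, would pull these two losses apart.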